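Nitro to methoxycarbonyl on the fused ring of compound 1

A few compounds are considered here, and "the series" means these few. Any claim that something is new, unique, unknown or untested is made for them only; others in the source may bear on it.

Measured compounds:
compound 1 `Nc1ccccc1NC(=O)c1ccc(CSC(=S)N2CCc3cc([N+](=O)[O-])ccc32)cc1`: 33.2%
compound 2 `CC1CCCCN1C(=S)SCc1ccc(C(=O)Nc2ccccc2N)cc1`: 86.9%
compound 3 `Nc1ccccc1NC(=O)c1ccc(CSC(=S)N2CCN(Cc3ccncc3)CC2)cc1`: 79.3%

The three measured compounds share a common amide core and differ in the amine attached to the thiocarbonyl. In a functional assay on MGC-803 cells (Homo sapiens) for antiproliferative activity, read by CCK-8 assay, with a stated time of 72 h, tested at 8 uM (a lower number here means a weaker effect, a higher number a stronger effect of the compound at the concentration tested), compound 1 gives 33.2%, the lowest of the three numbers. Compound 3 gives 79.3% in this assay, and compound 2 gives 86.9%; both stand above compound 1 by more than the usual scatter.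

Going by the values given here, compound 4 `COC(=O)c1ccc2c(c1)CCN2C(=S)SCc1ccc(C(=O)Nc2ccccc2N)cc1` keeps the fused two-ring amine of compound 1 and changes only one group: methoxycarbonyl in place of nitro on an aromatic carbon, set on an aromatic carbon of a six-membered aromatic ring of carbon only, part of a fused or bridged system of two rings. Among the compounds with values here, no pair of measured compounds differs at this position, so the data give no direct guide to the size of this step. Because compound 1 gives 33.2% while every other measured compound stands far higher, the step from compound 1 to compound 4 is expected to be a modest rise in this assay, estimated as a number 16.8 percentage points higher from compound 1 to compound 4 (beyond the scatter), though a value within the scatter of compound 1 cannot be ruled out. Compound 4 is therefore expected to give about 50% in this assay, within a range from 25% to 78%.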

Compound 4, a percentage reported as inhibition, at one concentration (the size of the read-out at that concentration, not a potency): 73.1%
Estimate against measurement, compound 4: 23.1 percentage points below, and the stated range covers the measured number.
By their numbers in this assay, from the lowest: compound 1; then compounds 4, 3 and 2 (each within the scatter of the next, the first and the last beyond it).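

In this assay, the group on this aromatic carbon proves to matter a great deal: methoxycarbonyl in place of nitro gives a number 39.9 percentage points higher from compound 1 to compound 4 (beyond the scatter), a large step from a single change. The low number of compound 1 therefore does not follow from its fused amine alone, since compound 4 keeps that amine and differs only in this one group. No measurement at hand explains the size of this step.

This single step cannot show which feature of the two groups matters, and it leaves open how a carboxylic acid, an amine or a nitrile on the same carbon would behave. Nor does it show whether the same exchange would give a step of similar size at another place on this ring.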